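The source may hold more compounds than are shown below. What is called first, only, known or untested is meant among the compounds shown, and "the series" means these compounds.

Compound 1 `CC1(C)[C@H]2CC[C@]1(C)N(Cc1cn(-c3cccc(Cl)c3)nn1)C(=O)C2`: 510 nM
Compound 2 `COc1ccccc1-n1cc(CN2C(=O)C[C@@H]3CC[C@@]2(C)C3(C)C)nn1`: 280 nM
Compound 3 `Cc1ccc(-n2cc(CN3C(=O)C[C@@H]4CC[C@@]3(C)C4(C)C)nn2)cc1`: 390 nM

In a functional assay on SGC-7901 cells (Homo sapiens) for inhibition, read by MTT assay, with a stated time of 24 h (a higher number here means a weaker inhibitor, a lower number a stronger inhibitor), compound 3 holds the second highest of the three numbers. Its steps from the other two, a 1.3-fold lower number from compound 1 to compound 3 (0.12 log units; within the scatter) and a 1.4-fold higher number from compound 2 to compound 3 (0.14 log units; within the scatter), both lie within the scatter, so the three aryl groups on the triazole nitrogen cannot be ranked against one another.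

Compound 4 `COc1cccc(-n2cc(CN3C(=O)C[C@@H]4CC[C@@]3(C)C4(C)C)nn2)c1` differs from compound 3 by one change: 3-methoxyphenyl in place of 4-methylphenyl on an aromatic nitrogen. For the measured compounds named here, the steps that bear on this change are the aryl swaps already measured, a 1.8-fold lower number from compound 1 to compound 2 (0.26 log units; within the scatter), a 1.3-fold lower number from compound 1 to compound 3 (0.12 log units; within the scatter) and a 1.4-fold higher number from compound 2 to compound 3 (0.14 log units; within the scatter), none of them beyond the scatter. Accordingly no step beyond the scatter is expected in this assay, and the step of a 1.0-fold lower number from compound 3 to compound 4 (0.01 log units; within the scatter) is estimated to be small.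

For compound 4 the expected value in this assay is 380 nM, with a range from 190 nM to 760 nM.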

Compound 4, half-maximal inhibitory concentration: 590 nM
Beside the measured number, compound 4's estimate is 1.6-fold (0.19 log units) below it; measured number inside the range.
By their numbers in this assay, from the lowest: compounds 2, 3, 1 and 4 (each within the scatter of the next, the first and the last beyond it).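

For the compounds shown here, compound 4 gives the first step beyond the scatter at this aromatic nitrogen in this assay with a 2.1-fold higher number from compound 2 to compound 4 (0.32 log units; beyond the scatter), a modest step between 2-methoxyphenyl and 3-methoxyphenyl. By contrast, a 1.5-fold higher number from compound 3 to compound 4 (0.18 log units; within the scatter) and a 1.2-fold higher number from compound 1 to compound 4 (0.06 log units; within the scatter) both stay within the scatter, so 3-methoxyphenyl cannot be told apart from 4-methylphenyl or 3-chlorophenyl. No measurement here explains the gap between the two methoxyphenyl groups. The compounds shown leave open whether that gap recurs with other groups on the phenyl ring. They also leave open how a phenyl ring carrying an amine or a carboxylic acid would read.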